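The source may report more compounds than this note shows. Statements on the series, on what has been measured and on what is new or still open speak of the compounds shown alone.

Of the compounds shown here, three built on one shared core have been measured in a functional assay on SW1573 cells (Homo sapiens) for antiproliferative activity; on this read-out higher numbers stand for lower toxicity in this test and lower numbers for higher toxicity in this test. Compound 1 `CC(C)CC1OCCC(Cl)=C1[Si](C)(C)C` gives 65000 nM in this assay, compound 2 `C[Si](C)(C)C1=C(Cl)C[C@H](C2CCCCC2)O[C@@H]1C1CCCCC1` gives 88000 nM, and compound 3 `C[C@@H]1O[C@H](C2CCCCC2)C([Si](C)(C)C)=C(Cl)[C@H]1C` gives 76000 nM. Compound 3 thus holds the second highest of the three numbers, and its gaps to compound 2 and to compound 1 both lie within the scatter. Compound 4 `C#CCC[C@H]1O[C@@H](C)[C@H](C)C(Cl)=C1[Si](C)(C)C` differs from compound 3 in one place: but-3-yn-1-yl in place of cyclohexyl on a saturated ring carbon. Among the measured compounds shown here, no step of this kind has been measured, so nothing is known that would move the expectation away from the value of compound 3, 76000 nM. Compound 4 is therefore expected to give about 75000 nM, between 40000 nM and 140000 nM, an expected step of a 1.0-fold lower number from compound 3 to compound 4 (0.01 log units; within the scatter) that stays within the scatter.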

Compound 4, concentration lethal to 50% of the cells: 75000 nM
Beside the measured number, compound 4's estimate shows no gap at the digits printed; the measured number falls inside the stated range.
By their numbers in this assay, from the lowest: compounds 1, 4, 3 and 2 (each within the scatter of the next).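

In this assay, replacing cyclohexyl with but-3-yn-1-yl on the saturated ring carbon next to the ring oxygen gives a 1.0-fold lower number from compound 3 to compound 4 (0.01 log units; within the scatter). This first one-place comparison shows that, in this setting, the two groups cannot be told apart, although one has a ring and the other a triple bond and fewer heavy atoms. No supporting data address why they read alike. As far as these compounds go, whether an amine or a carboxylic acid at this ring carbon would stay in the same range remains open. So does the contribution of the chloro and methyl groups, since no step shown changes them alone.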